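The source may report more compounds than this note shows. Statements on the series, on what has been measured and on what is new or still open speak of the compounds shown alone.

Going by the values given here, compound 1 `Cc1ccc(-c2cc(N)n(-c3cccc(Cl)c3)n2)cc1` is the only member of this small set that returns a number in a functional assay on Jurkat cells (Homo sapiens) for inhibition, read by MTT assay, with a stated time of 72 h; on this read-out lower numbers stand for stronger inhibition of growth and higher numbers for weaker inhibition of growth: compound 1 gives 56600 nM. Compound 2 `Nc1cc(-c2ccc(Cl)cc2)nn1-c1cccc(Cl)c1` stops at a limit of the assay, > 100000 nM. Compound 3 `Cc1ccc(-c2cc(/N=C/N(C)C)n(-c3cccc(Cl)c3)n2)cc1` also stops at a limit of the assay, > 100000 nM. Two single-point steps away from compound 1 are therefore known: an at least 1.7-fold higher number from compound 1 to compound 2 (0.24 log units; that floor lies within the scatter), with chloro in place of methyl on an aromatic carbon, and an at least 1.7-fold higher number from compound 1 to compound 3 (0.24 log units; that floor lies within the scatter), with a group of 5 heavy atoms in place of one nitrogen atom on an aromatic carbon. Both end at the limit of > 100000 nM in this assay, at which 2 of the 3 values shown sit, so neither step has a measured size beyond its floor.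

Compound 4 `Cc1ccc(-c2nn(-c3cccc(Cl)c3)c(N)c2C=O)cc1` differs from compound 1 by formyl in place of hydrogen on an aromatic carbon. Among the compounds with values here, no measured step touches that position of the shared core or introduces a formyl group, so the two known steps bear on it only loosely: they show that the core of compound 1 sits close to the limit and that changes elsewhere have not produced a stronger number. No step beyond the scatter is expected in this assay for compound 4, and a weaker outcome remains possible. Compound 4 is estimated at 65000 nM, with a range from 25000 nM to 100000 nM. The step this estimate implies, a 1.1-fold higher number from compound 1 to compound 4 (0.06 log units; within the scatter), is expected to stay within the scatter.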

Compound 4, concentration for 50% growth inhibition: 86300 nM
The estimate for compound 4 lay 1.3-fold (0.12 log units) below the measured number; the range from low to high includes it.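

Formyl in place of hydrogen on the aromatic carbon next to the ring atom that bears an amino group gives the first step in this assay that has a number at both ends, a 1.5-fold higher number from compound 1 to compound 4 (0.18 log units; within the scatter). This step lies within the scatter, so the read-out does not separate compound 4 from compound 1, and this position of the shared core carries a formyl group with no measurable shift in either direction. The earlier steps shown here could not show this, since each of them ends at a limit and not at a number, and so gives only a floor: the limit of > 100000 nM in this assay, at which 2 of the 4 values shown sit.

The compounds shown leave open whether any other group on this same carbon, such as a carboxylic acid, a nitrile, an amine or a longer chain, would move the number beyond the scatter in either direction. They also leave open whether formyl at this position would give the same result with chloro in place of the methyl of the 4-methylphenyl group, or with the amino group replaced by the longer group that compound 3 carries.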